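Ethyl for methyl on the ring nitrogen of compound 2

The source may report more compounds than this note shows. Statements on the series, on what has been measured and on what is new or still open speak of the compounds shown alone.

The series has two measured members. Compound 1 `CCC(=O)NC[C@@H]1CN(C)c2ccccc2[C@@H]1c1ccccc1` gives 3.4 nM in an assay on cells for displacement of a labelled ligand from melatonin receptor type 1A (Homo sapiens), read by filter binding, with a stated time of 120 min; on this read-out higher numbers stand for weaker inhibition and lower numbers for stronger inhibition. Compound 2 `CC(=O)NCC1Cc2ccccc2N(C)C1` gives 83 nM in this assay and so stands at the higher of the two numbers; its gap to compound 1 lies beyond the usual scatter, but the two compounds differ in several places at once, so nothing is ascribed to any single part of that gap.

Compound 3 `CCN1CC(CNC(C)=O)Cc2ccccc21` is the next member. Against compound 2 the change is methyl in place of hydrogen on a saturated chain carbon bound to a nitrogen on an aromatic ring in a ring. Going by the values given here, no measured pair shows the effect of such a change on the nitrogen on the aromatic ring. With only a single carbon added at a site where compound 1 and compound 2 both carry methyl, the expectation is a step from compound 2 to compound 3 of a 1.0-fold higher number from compound 2 to compound 3 (0.01 log units; within the scatter), that is, none beyond the scatter. For compound 3 the estimated value in this assay is 85 nM, with a range from 30 nM to 250 nM.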

Compound 3, inhibition constant: 20 nM
Compound 3: middle estimate off by 4.3-fold (0.63 log units), on the high side, and the stated range ends above it.
By their numbers in this assay, from the lowest: compound 1; then compound 3; then compound 2.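

Going by these compounds alone, compound 2 and compound 3 form the first pair that differ in one place, and they show that the group on the nitrogen on an aromatic ring affects the result in this assay: methyl to ethyl gives a 4.2-fold lower number from compound 2 to compound 3 (0.62 log units; beyond the scatter). The step is modest, but it lies beyond the scatter, so at this position the added carbon goes with stronger inhibition rather than leaving the number unchanged. No measurement at hand bears on the reason for this step.

As far as these compounds go, a single step sets no trend, so it remains open whether a longer chain such as propyl, or a branched group such as isopropyl, on this nitrogen would continue in the same direction. Also open, from the compounds shown here alone, is whether methyl to ethyl would give a similar step on the core of compound 1.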